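A small ring in place of a methyl on the amide

A few compounds are considered here, and "the series" means these few. Any claim that something is new, unique, unknown or untested is made for them only; others in the source may bear on it.

Measured so far:
compound 1, `CC(=O)Nc1ccn([C@@H]2CO[C@H](CO)O2)c(=O)n1` — 10700 nM
compound 2, `CCCCCCCCCCCCCCCCCCCCCC(=O)Nc1ccn([C@@H]2CO[C@H](CO)O2)c(=O)n1` — 900 nM

Both compounds share the same core and differ only in the group carried on the amide carbonyl. In a functional assay on SW1573 cells (Homo sapiens) for cytotoxicity, read by sulforhodamine B assay, with a stated time of 72 h (a higher number here means a weaker inhibitor, a lower number a stronger inhibitor), compound 1 gives 10700 nM, the higher of the two numbers, so it is the weaker of the pair. Compound 2, with a long chain in that place, gives 900 nM in this assay, a difference well beyond the scatter of repeat measurements. Compound 3, `O=C(Nc1ccn([C@@H]2CO[C@H](CO)O2)c(=O)n1)C1CC1`, is the next step from compound 1: cyclopropyl in place of methyl on a carbonyl carbon. Among the measured compounds shown here, no pair of measured compounds shows this exact change, so the expectation rests on compound 1 alone. A change of only a few atoms at the same position is expected to move the number little, perhaps somewhat downward, with a step of a 1.6-fold lower number from compound 1 to compound 3 (0.22 log units; within the scatter). Compound 3 is therefore estimated at 6500 nM, within a range from 2500 nM to 16000 nM.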

Compound 3, half-maximal inhibitory concentration: 22000 nM
Compound 3: middle estimate off by 3.4-fold (0.53 log units), on the low side; measured number outside the range, above it.
By their numbers in this assay, from the lowest: compound 2; then compound 1; then compound 3.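

Cyclopropyl in place of methyl on the carbonyl carbon gives a 2.1-fold higher number from compound 1 to compound 3 (0.31 log units; beyond the scatter) in this assay and so makes the compound a weaker inhibitor, by a modest step that still lies beyond the scatter. Among the compounds shown here, until now, the only change seen at this position was the long chain of compound 2, which has a lower number than compound 1; compound 3 goes against any simple rule that more carbon here lowers the number. Nothing measured here explains why this small ring raises the number.

Still open, from the compounds shown here alone, is how the number would respond to a butyl chain, which is far shorter than the chain of compound 2, on the same carbonyl carbon. A cyclohexyl or phenyl ring there would show whether larger rings follow cyclopropyl upward.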